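Moving the Ester Around the Pyridine Ring

The compounds below may be only part of what the source reports. "The series", "measured", "known", "first", "only" and "open" are said of these compounds alone.

Compound 1 `COC(=O)c1ccc(-c2cnc(C(O)CCc3ccc(-c4ccccc4)cc3)o2)nc1` is an alcohol whose core carries a pyridine bearing a methoxycarbonyl group. In an assay for inhibition of Fatty-acid amide hydrolase 1 (Rattus norvegicus) (a lower number here means a stronger inhibitor, a higher number a weaker inhibitor), compound 1 gives 1100 nM, the second highest of the three numbers shown. Compound 2 `N#Cc1cnc(C(=O)CCc2ccc(Oc3ccccc3)cc2)o1`, a ketone with a nitrile and a phenoxy group, gives 0.8 nM in this assay. Compound 3 `COC(=O)c1ccc(-c2cnc(CCCc3ccc(-c4ccccc4)cc3)o2)nc1` carries hydrogen in place of the hydroxy group of compound 1; in this assay compound 3 gives 50000 nM, and the step of a 45-fold higher number from compound 1 to compound 3 (1.66 log units; beyond the scatter) shows how much that hydroxy group counts for.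

Compound 4 `COC(=O)c1cccc(-c2cnc(C(O)CCc3ccc(-c4ccccc4)cc3)o2)n1` has not yet been measured. It differs from compound 1 by 6-(methoxycarbonyl)pyridin-2-yl in place of 5-(methoxycarbonyl)pyridin-2-yl on an aromatic carbon. Among the compounds with values here, no measured pair tests a change of this kind: the only step, a 45-fold higher number from compound 1 to compound 3 (1.66 log units; beyond the scatter), concerns the hydroxy group, and compound 2 differs from compound 1 in several places at once. The expectation therefore rests on compound 1 alone and carries a wide range. Compound 4 is expected to give 2000 nM in this assay, between 500 nM and 8000 nM. This estimate means a step of a 1.8-fold higher number from compound 1 to compound 4 (0.26 log units; within the scatter), expected to stay within the usual scatter.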

Compound 4, inhibition constant: 9000 nM
The estimate for compound 4 lay 4.5-fold (0.65 log units) below the measured number, and the stated range ends below it.
By their numbers in this assay, from the lowest: compound 2; then compound 1; then compound 4; then compound 3.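

The two compounds have the same atoms, and 6-(methoxycarbonyl)pyridin-2-yl in place of 5-(methoxycarbonyl)pyridin-2-yl gives an 8.2-fold higher number from compound 1 to compound 4 (0.91 log units; beyond the scatter) in this assay, a step beyond the usual scatter. The earlier step concerned the hydroxy group on the chain, whereas this one shows that the number also responds to a change at the other end of the molecule, on the aromatic carbon next to the ring oxygen. Here, only the place of attachment within the methoxycarbonyl-bearing pyridine differs, so no group has been added or removed.

The compounds shown leave open whether the methoxycarbonyl group itself matters, which a carboxylic acid or an amide in its place would test. Nothing shown here explains why this change raises the number.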